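This account rests on a few compounds, and the source may have more. Where it says the series, first, only, none or still open, it means among the compounds named here.

Measured so far:
compound 1 `O=S(=O)(NCCCNCc1ccc(Cl)cc1)c1cc(C(F)(F)F)cc(C(F)(F)F)c1`: 2800 nM
compound 2 `O=S(=O)(NCCCNCc1ccc(C(F)(F)F)cc1)c1cc(C(F)(F)F)cc(C(F)(F)F)c1`: 2700 nM
compound 3 `CN(CCCNS(=O)(=O)c1cc(C(F)(F)F)cc(C(F)(F)F)c1)Cc1ccccc1`: 30000 nM

In a functional assay on HPAC cells (Homo sapiens) for inhibition, read by MTT assay, with a stated time of 72 h (a higher number here means a weaker inhibitor of growth, a lower number a stronger inhibitor of growth), compound 3 gives the highest of the three numbers. Compound 4 `O=S(=O)(NCCCNCc1ccc(Br)cc1)c1cc(C(F)(F)F)cc(C(F)(F)F)c1` differs from it by (4-bromobenzyl)amino in place of benzyl(methyl)amino on a saturated chain carbon, three bonds along the chain from a sulfonamide nitrogen. Among the compounds with values here, two measured steps bear on this. The step of an 11-fold higher number from compound 1 to compound 3 (1.03 log units; beyond the scatter) is the reverse of the present change except for the halogen, so its reversal should return most of that distance. The step of a 1.0-fold lower number from compound 1 to compound 2 (0.02 log units; within the scatter) shows that swapping the substituent on that benzyl ring leaves the number within the scatter, so the bromo analogue is expected to sit close to compound 1 and compound 2. For compound 4 a step of an 11-fold lower number from compound 3 to compound 4 (1.03 log units; beyond the scatter) in this assay is therefore expected, a lower number. Compound 4 is estimated at 2800 nM, with a range from 1200 nM to 6500 nM.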

Compound 4, concentration for 50% growth inhibition: 2900 nM
Beside the measured number, compound 4's estimate is 1.0-fold (0.02 log units) below it; the measured number falls inside the stated range.
By their numbers in this assay, from the lowest: compounds 2, 1 and 4 (each within the scatter of the next); then compound 3.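

In this assay the change gives a 10-fold lower number from compound 3 to compound 4 (1.01 log units; beyond the scatter), a large step that joins loss of the nitrogen methyl with gain of the ring bromo. Bromo is indistinguishable from the other ring substituents, with a 1.1-fold higher number from compound 2 to compound 4 (0.03 log units; within the scatter) and a 1.0-fold higher number from compound 1 to compound 4 (0.02 log units; within the scatter), so three para-type variants now sit together on the secondary amine. No measurement here accounts for the large step.

The two parts of that step remain unseparated: (4-bromobenzyl)(methyl)amino and unsubstituted benzylamino would divide it. Going by these compounds, whether a methoxy group on the ring also holds the number remains open.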